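Trimethoxy in place of dimethoxy on the aryl of compound 1

This account rests on a few compounds, and the source may have more. Where it says the series, first, only, none or still open, it means among the compounds named here.

Compound 1 `COc1ccc(/C=C/C(=O)c2cc(-c3ccc(OC)c(OC)c3)n3nc(-c4ccccc4)cc3n2)cc1` is the reference of this set. In a functional assay on MDA-MB-231 cells (Homo sapiens) for antiproliferative activity, read by MTT assay, with a stated time of 24 h (on this read-out higher numbers stand for weaker inhibition and lower numbers for stronger inhibition), compound 1 gives 22000 nM, the highest of the three numbers recorded, though its steps to the other two compounds stay within the scatter. Compound 2 `COc1ccc(-c2cc(/C=C/C(=O)c3ccc(C)cc3)nc3cc(-c4ccccc4)nn23)cc1OC` gives 19800 nM in this assay, and compound 3 `COc1ccc(-c2cc(/C=C/C(=O)c3ccc(C)c(C)c3)nc3cc(-c4ccccc4)nn23)cc1OC` gives 11500 nM. The steps of a 1.1-fold lower number from compound 1 to compound 2 (0.05 log units; within the scatter) and a 1.9-fold lower number from compound 1 to compound 3 (0.28 log units; within the scatter) both alter the enone side of the shared core; the step of a 1.7-fold lower number from compound 2 to compound 3 (0.24 log units; within the scatter) is the only one that adds a methyl in place of hydrogen on an aromatic carbon, and it too stays within the scatter.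

Compound 4 `COc1ccc(/C=C/C(=O)c2cc(-c3cc(OC)c(OC)c(OC)c3)n3nc(-c4ccccc4)cc3n2)cc1` differs from compound 1 by methoxy in place of hydrogen on an aromatic carbon. Within the data shown here, none of the measured steps touch this ring, so no direct precedent exists; the small, scatter-bound steps seen elsewhere give no ground to expect a shift beyond the scatter. The expected step is a 1.2-fold lower number from compound 1 to compound 4 (0.09 log units; within the scatter). Compound 4 is estimated at 18000 nM in this assay, within 7000 nM to 50000 nM.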

Compound 4, half-maximal inhibitory concentration: 16500 nM
Estimate against measurement, compound 4: 1.1-fold (0.04 log units) above; the measured number falls inside the stated range.
By their numbers in this assay, from the lowest: compounds 3, 4, 2 and 1 (each within the scatter of the next).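

Among these compounds, the move from 3,4-dimethoxyphenyl to 3,4,5-trimethoxyphenyl is the first step in this set that touches this aryl ring, and in this assay it reads as a 1.3-fold lower number from compound 1 to compound 4 (0.12 log units; within the scatter). A methoxy on this aromatic carbon, ortho to a methoxy group, therefore leaves compound 4 within the scatter of compound 1, so this ring now joins the enone side as a region where every step shown stays within the scatter. Nothing measured here gives a reason for this result.

Going by these compounds, whether an amine, a carboxylic acid or a longer chain such as butoxy on this same carbon would give a step beyond the scatter remains open. Also open, on these data alone, is whether a hydroxyl or a fluorine in place of one of the existing methoxy groups would do so.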